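This account rests on a few compounds, and the source may have more. Where it says the series, first, only, none or still open, it means among the compounds named here.

In a functional assay on Jurkat cells (Homo sapiens) for antiproliferative activity, read by MTT assay (on this read-out lower numbers stand for stronger inhibition and higher numbers for weaker inhibition), compound 1 `COc1ccccc1/C=C1\CCc2cc(OC)c(OC)cc2C1=O` gives > 50000 nM, which is a limit of the assay and not a number. Compound 2 `COc1cc2c(cc1OC)C(=O)/C(=C/c1cccc(OC)c1OC)CC2` gives > 50000 nM, and this too is only a limit. Both compounds thus share one boundary: the limit of > 50000 nM in this assay, at which 2 of the 2 values shown sit. Neither compound has a measured potency, so the starting point is known only from one side.

Compound 3 `COc1cc2c(cc1OC)C(=O)/C(=C/c1cc(C)cc(C)c1)CC2` carries 3,5-dimethylphenyl in place of 2-methoxyphenyl on a double-bonded chain carbon bound to a double-bonded ring carbon.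

Within the data shown here, the only measured step is a step that the two limits leave unreadable from compound 1 to compound 2, so it offers no size to carry over to this change, and no clear shift in either direction can be predicted. The expected change is an at least 1.2-fold lower number from compound 1 to compound 3 (0.09 log units; that floor lies within the scatter), which is no confident move beyond the scatter. For compound 3 the estimate is 40000 nM, with an expected range from 10000 nM to 100000 nM.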

Compound 3, half-maximal inhibitory concentration: 4000 nM
The estimate for compound 3 lay 10-fold (1.00 log units) above the measured number; the whole stated range lies above it.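

Replacing 2-methoxyphenyl with 3,5-dimethylphenyl on a double-bonded chain carbon bound to a double-bonded ring carbon gives an at least 12-fold lower number from compound 1 to compound 3 (1.09 log units; beyond the scatter) in this assay. This shows that the aromatic ring at this place can decide whether the shared core has measurable activity, something the earlier pair could not show, as the step between compound 1 and compound 2 cannot be read. Compound 3 gives a true number, while the other two compounds stay at an assay limit: the limit of > 50000 nM in this assay, at which 2 of the 3 values shown sit.

The compounds shown do not separate the loss of the methoxy group from the arrival of the methyl groups, as both happen in the one change. They also leave open how this ring would behave if it carried an amine, a carboxylic acid or a longer chain such as propyl.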